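The source may hold more compounds than are shown below. What is called first, only, known or untested is meant among the compounds shown, and "the series" means these compounds.

Measured compounds:

Compound 1, `COc1ccn2ncc(/C=N/N(C)S(=O)(=O)c3cc([N+](=O)[O-])ccc3C)c2c1`. In an assay on isolated protein for inhibition of phosphatidylinositol 4,5-bisphosphate 3-kinase catalytic subunit beta isoform (Homo sapiens), read by 33P incorporation, with a stated time of 60 min (a higher number here means a weaker inhibitor, a lower number a stronger inhibitor), compound 1 gives > 1000 nM, which is a limit of the assay and not a number.
Compound 2, `Cc1ccc([N+](=O)[O-])cc1S(=O)(=O)N(C)/N=C/c1cnn2ccc(Br)cc12`. In this assay compound 2 gives 230 nM.
Compound 3, `Cc1ccc([N+](=O)[O-])cc1S(=O)(=O)N(C)/N=C/c1cnn2ccc(C3CC3)cc12`. In this assay compound 3 gives > 1000 nM, again a limit of the assay.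

Compound 1 therefore stands at the limit of > 1000 nM in this assay, at which 2 of the 3 values shown sit; only compound 2 gives a readable number. The step from compound 1 to compound 2 is an at least 4.3-fold lower number from compound 1 to compound 2 (0.63 log units; beyond the scatter). The step from compound 1 to compound 3 is a step that the two limits leave unreadable from compound 1 to compound 3. From compound 2 to compound 3 the step is an at least 4.3-fold higher number from compound 2 to compound 3 (0.63 log units; beyond the scatter), so at this position bromo gives a number where methoxy and cyclopropyl give only the limit.

The next compound is compound 4, `C#Cc1ccn2ncc(/C=N/N(C)S(=O)(=O)c3cc([N+](=O)[O-])ccc3C)c2c1`. It differs from compound 1 by ethynyl in place of methoxy on an aromatic carbon. Among the compounds with values here, none of the measured steps uses ethynyl, so the bromo result and the cyclopropyl result pull in opposite directions, and the change from compound 1 is expected to give a modest drop at best, an at least 1.6-fold lower number from compound 1 to compound 4 (0.22 log units; that floor lies within the scatter). Compound 4 is estimated at 600 nM in this assay, within the range 150 nM to 2500 nM, with a real chance that the assay again reports only its limit.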

Compound 4, half-maximal inhibitory concentration: 30 nM
Beside the measured number, compound 4's estimate is 20-fold (1.30 log units) above it; measured number outside the range, below it.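

In this assay, within the data shown here, this position, opposite the ring nitrogen, proves able to carry far more than the earlier compounds showed: ethynyl in place of methoxy gives an at least 33-fold lower number from compound 1 to compound 4 (1.52 log units; beyond the scatter), and ethynyl in place of cyclopropyl gives an at least 33-fold lower number from compound 3 to compound 4 (1.52 log units; beyond the scatter). Bromo had been the only group with a readable number here, and ethynyl now goes past it, with a 7.7-fold lower number from compound 2 to compound 4 (0.88 log units; beyond the scatter), while methoxy and ethynyl each count 2 heavy atoms, so that count alone does not separate the two groups and the change removes 1 hydrogen-bond acceptor. Compound 1 and compound 3 remain limits of the assay and not numbers, so the two large steps from them are floors whose full size stays unread: the limit of > 1000 nM in this assay, at which 2 of the 4 values shown sit.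

From the compounds shown here alone, whether the gain needs the triple bond stays open, and a nitrile or a propynyl group at this position would test that directly. Also open, going by these compounds, is whether the ethynyl result holds when the core of compound 4 changes elsewhere, for instance with an amine in place of the nitro group.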